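Benzylation of a bicyclic amidine core: an expected gain

The compounds below may be only part of what the source reports. "The series", "measured", "known", "first", "only" and "open" are said of these compounds alone.

Compound 1 `COc1ccc(Cn2cc3cc(C(=N)Nc4ccc(N5CCN(C)CC5)cc4)ncc3n2)cc1` gives 9900 nM in a functional assay on PC-3 cells (Homo sapiens) for cytotoxicity, read by MTT assay, with a stated time of 72 h; a higher number here means a weaker inhibitor, a lower number a stronger inhibitor.
Compound 2 `CN1CCN(c2ccc(NC(=N)c3cc4cn(C)nc4cn3)cc2)CC1` gives 24800 nM in this assay.
Compound 3 `CN1CCN(c2ccc(NC(=N)c3cc4cnn(C)c4cn3)cc2)CC1` gives 32300 nM in this assay.

The three measured compounds share the same amidine and methylpiperazinyl-phenyl portion and differ in the bicyclic core and in what sits on its ring nitrogen. Compound 2 and compound 3 are built from the same atoms joined differently; the difference between the two cores is not broken down here. Their values in this assay sit close together and within the scatter, so nothing is read from their order.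

Among the compounds with values here, the one change that is seen twice is 4-methoxyphenyl in place of hydrogen on a saturated chain carbon bound to an aromatic nitrogen. On the core of compound 2 it gave a 2.5-fold lower number from compound 2 to compound 1 (0.40 log units; beyond the scatter), a modest but real gain.

Compound 4 `COc1ccc(Cn2ncc3cc(C(=N)Nc4ccc(N5CCN(C)CC5)cc4)ncc32)cc1` has not yet been measured in this assay. It relates to compound 3 exactly as compound 1 relates to compound 2: the change is 4-methoxyphenyl in place of hydrogen on a saturated chain carbon bound to an aromatic nitrogen, made at the same kind of place, and here it is the same change on the other core. Within the data shown here, on the strength of the single earlier step, the expected step from compound 3 to compound 4 is a 2.3-fold lower number from compound 3 to compound 4 (0.36 log units; beyond the scatter), which rests on compound 2 to compound 1 giving a 2.5-fold lower number from compound 2 to compound 1 (0.40 log units; beyond the scatter) and on nothing else, since no second example exists. Compound 4 is therefore estimated at 14000 nM, with a likely range from 6000 nM to 35000 nM.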

Compound 4, half-maximal inhibitory concentration: 6100 nM
Beside the measured number, compound 4's estimate is 2.3-fold (0.36 log units) above it; measured number inside the range.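

In this assay, methyl to 4-methoxybenzyl on the second core gave a 5.3-fold lower number from compound 3 to compound 4 (0.72 log units; beyond the scatter), so the number fell on both cores and this step is beyond the scatter, as the earlier one was. Set side by side, the two steps share a direction and cannot be told apart in size: the same change on two cores in this assay, a 2.5-fold lower number (0.40 log units; beyond the scatter) from compound 2 to compound 1 and a 5.3-fold lower number (0.72 log units; beyond the scatter) from compound 3 to compound 4, 2.1-fold (0.33 log units) apart, within the scatter of two such steps The larger figure on the second core therefore does not show that this core gains more from the change, and two matched pairs in one cell assay show only that the change carried across these two cores, not that it would carry to any other core or that the same size of gain should be expected elsewhere.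

The compounds shown leave open which part of the 4-methoxybenzyl group goes with the lower number, since a plain benzyl group or a propyl chain in its place would separate the aromatic ring and its methoxy group from simple chain length. Also open, as far as these compounds go, is whether the step would hold if the methylpiperazinyl portion, constant across all four compounds, gave way to a morpholine.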